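Adding a Methyl to Compound 3: What to Expect

The compounds below may be only part of what the source reports. "The series", "measured", "known", "first", "only" and "open" are said of these compounds alone.

Of the compounds shown here, three have been measured in a functional assay on HUVEC cells (Homo sapiens) for inhibition, with a stated time of 4 days; a higher number here means a weaker inhibitor, a lower number a stronger inhibitor. Compound 1 `COc1ccc(C(N)=O)cc1COc1ccc(Cl)c(C)c1` gives 640 nM in this assay, and compound 2 `COc1ccc(C(N)=O)cc1COc1ccc(Cl)cc1` gives 660 nM. These two differ in a single place, described as methyl in place of hydrogen on an aromatic carbon. The result of that change was a 1.0-fold lower number from compound 2 to compound 1 (0.01 log units; within the scatter), so the added methyl left the potency essentially unchanged.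

Compound 3 `COc1ccc(C(N)=O)cc1/C=C/c1ccccc1` is built on a different core; how its core differs from that of compound 2 is not broken down here. In this assay compound 3 gives 2400 nM, the highest of the three numbers, and its distance from each of the other two lies beyond the usual scatter.

Compound 4 `COc1ccc(C(N)=O)cc1/C=C/c1cccc(C)c1` has not yet been measured. It differs from compound 3 in one place, described as methyl in place of hydrogen on an aromatic carbon. This is the same kind of change as that from compound 2 to compound 1, but not the same change: in compound 1 the methyl sits ortho to a chloro group as well as meta to a large group, whereas in compound 4 it sits only meta to a large group, with no chloro group on that ring.

Compound 4 is expected to give about 2300 nM, with a likely range from 1100 nM to 5000 nM. The expected step is a 1.0-fold lower number from compound 3 to compound 4 (0.02 log units; within the scatter), which rests on the earlier methyl addition because a 1.0-fold lower number from compound 2 to compound 1 (0.01 log units; within the scatter) stayed within the scatter. The measured value will show whether the new core behaves alike.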

Compound 4, half-maximal inhibitory concentration: 3900 nM
For compound 4 the middle estimate is 1.7-fold (0.23 log units) below the measured one; the range from low to high includes it.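

In this assay the methyl step on the newer core comes out as a 1.6-fold higher number from compound 3 to compound 4 (0.21 log units; within the scatter), so here too the added methyl produces no change that can be told apart from the noise of repeated measurement. Set beside the earlier step, the two results give no sign that this change behaves differently on the two cores: the same change on two cores in this assay, a 1.0-fold lower number (0.01 log units; within the scatter) from compound 2 to compound 1 and a 1.6-fold higher number (0.21 log units; within the scatter) from compound 3 to compound 4, 1.7-fold (0.22 log units) apart, within the scatter of two such steps This does not prove that a methyl is without effect in this series, since two pairs are few, a small real shift could hide inside the scatter, and the methyl has a different environment in each pair, with a chloro group on the ring of compound 1 and none on the ring of compound 4.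

The compounds shown leave open whether a longer chain, an amine or a carboxylic acid in place of this methyl would also leave the number within the scatter of compound 3. They also leave open what a methyl would do elsewhere on that ring, and whether the agreement seen on these two cores would hold on a third.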